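The source may report more compounds than this note shows. Statements on the series, on what has been measured and on what is new or still open speak of the compounds shown alone.

Measured compounds in an ADME assay on BaF3 cells (Mus musculus) for antiproliferative activity; a lower number here means a stronger inhibitor of growth, a higher number a weaker inhibitor of growth:
compound 1, `Cc1ccc(NC(=O)c2cccc(C(F)(F)F)c2)cc1OCCNC(=O)c1cccnc1`: > 10000 nM, a limit of the assay.
compound 2, `O=C(Nc1cccc(OC2CCN(C(=O)c3cccnc3)CC2)c1)c1cccc(C(F)(F)F)c1`: > 10000 nM, a limit of the assay.

Compound 2 stands only at a limit of this assay; no number is known for it. Going by the values given here, the same holds for compound 1, so the series so far offers no measured step, only (the limit of > 10000 nM in this assay, at which 2 of the 2 values shown sit). Compound 3, `COc1ccc(NC(=O)c2cccc(C(F)(F)F)c2)cc1OC1CCN(C(=O)c2cccnc2)CC1`, is not yet measured. It differs from compound 2 by methoxy in place of hydrogen on an aromatic carbon. Among the compounds with values here, with both known values sitting at the limit there is no measured step to lean on, and no effect of the methoxy is known within this set. The expected step from compound 2 to compound 3 is a step that the limit leaves unreadable from compound 2 to compound 3, none beyond the scatter. Compound 3 is thus estimated at 15000 nM, with a range of 5000 nM to 40000 nM, and most likely reported again only as a limit.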

Compound 3, concentration for 50% growth inhibition: > 10000 nM
Compound 3 was reported as a limit (the forecaster's own chance of this, stated with the estimate: 80%); the middle value lies beyond the limit too.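

No step can be read between compound 2 and compound 3 in this assay, because both stand only at a limit: the limit of > 10000 nM in this assay, at which 3 of the 3 values shown sit.

Still open, as far as these compounds go, is whether methoxy in place of hydrogen on an aromatic carbon alters growth inhibition at all, and which structural change would give a measurable value.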